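A few compounds are considered here, and "the series" means these few. Any claim that something is new, unique, unknown or untested is made for them only; others in the source may bear on it.

Working notes on the series. In a functional assay on PC-3 cells (Homo sapiens) for antiproliferative activity, read by MTT assay, with a stated time of 72 h (on this read-out higher numbers stand for weaker inhibition and lower numbers for stronger inhibition), compound 1 `O=C(N/N=C/c1cccc([N+](=O)[O-])c1)Nc1ccc(Oc2ccnc3[nH]ccc23)c(F)c1` gives 5140 nM and compound 2 `COc1ccc(/C=N/NC(=O)Nc2ccc(Oc3ccnc4[nH]ccc34)c(F)c2)cc1` gives 6730 nM. For the measured compounds named here, compound 2 therefore holds the higher of only two numbers, but the gap between them lies within the scatter, so the pair cannot be ranked and both sit in the same low-micromolar band.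

The next step leads to compound 3 `O=C(N/N=C/c1ccc(O)c(Br)c1)Nc1ccc(Oc2ccnc3[nH]ccc23)c(F)c1`, with the shared core unchanged: 3-bromo-4-hydroxyphenyl in place of 4-methoxyphenyl on a carbon with a double bond to nitrogen.

Going by the values given here, one measured step bears on this change, a 1.3-fold higher number from compound 1 to compound 2 (0.12 log units; within the scatter). It concerns the same place on the molecule and stays small. Among the compounds with values here, no measured compound carries the 3-bromo-4-hydroxyphenyl group, so the evidence is thin, and the range has to stay wider than the scatter alone. In this assay, from the compounds shown here alone, no step beyond the scatter is expected, and the direction remains open.

The estimated step is a 1.3-fold lower number from compound 2 to compound 3 (0.13 log units; within the scatter).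

For compound 3 the expected value is 5000 nM, with an estimated range of 1700 nM to 14000 nM.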

Compound 3, half-maximal inhibitory concentration: 28600 nM
Compound 3: the middle estimate sits 5.7-fold (0.76 log units) below what was measured; measured number outside the range, above it.
By their numbers in this assay, from the lowest: compounds 1 and 2 (each within the scatter of the next); then compound 3.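

In this assay the place on the carbon with a double bond to nitrogen proved not to be indifferent to the group it carries: the 3-bromo-4-hydroxyphenyl group gives a 4.2-fold higher number from compound 2 to compound 3 (0.63 log units; beyond the scatter) and also a 5.6-fold higher number from compound 1 to compound 3 (0.75 log units; beyond the scatter) in the same direction, both beyond the scatter, whereas compound 1 and compound 2 could not be told apart. The exchange of 4-methoxyphenyl for 3-bromo-4-hydroxyphenyl leaves the count at 8 heavy atoms, yet it brings in bromine and 1 hydrogen-bond donor, so a change of this kind at this place can weaken inhibition on this read-out even when the size of the group, counted in heavy atoms, stays the same. No measurement is available that ties the step to any one feature of the entering group.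

The compounds shown do not separate the bromine from the hydroxyl, so what a plain 3-bromophenyl or 4-hydroxyphenyl group would give here remains open. Also open, from the compounds shown here alone, is whether an aminophenyl or a carboxyphenyl group at this place would stay in the band of compound 1 and compound 2 or fall with compound 3.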